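Removing a chloro on two different rings in one inhibitor series

A few compounds are considered here, and "the series" means these few. Any claim that something is new, unique, unknown or untested is made for them only; others in the source may bear on it.

Three thiourea-linked piperidine compounds were tested in an assay on membranes from brain for binding affinity to Lysophosphatidylserine lipase ABHD12 (Mus musculus), read by fluorescence, with a stated time of 20 min; a lower number here means a stronger inhibitor, a higher number a weaker inhibitor. Compound 1 `FC(F)(F)Oc1ccc(Oc2ccnc(N3CCC(NC(=S)Nc4cccnc4)CC3)c2Cl)cc1` gives 25 nM. Compound 3 `FC(F)(F)Oc1ccc(Oc2ccnc(N3CCC(NC(=S)Nc4cccnc4)CC3)c2Cl)cc1Cl` gives 33 nM. Compound 2 `FC(F)(F)c1cnc(N2CCC(NC(=S)Nc3cccnc3)CC2)c(Cl)c1` gives 1100 nM, the highest of the three numbers, and its gap to both others lies beyond the scatter.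

Compound 3 and compound 1 differ by one change, (hydrogen in place of chloro on an aromatic carbon), and the step is a 1.3-fold lower number from compound 3 to compound 1 (0.12 log units; within the scatter). Compound 4 `FC(F)(F)c1ccc(N2CCC(NC(=S)Nc3cccnc3)CC2)nc1` is not yet measured; it differs from compound 2 by hydrogen in place of chloro on an aromatic carbon. This is the same kind of change, but the place is not the same: in compound 3 the chloro sits on a six-membered aromatic ring of carbon only, ortho to a trifluoromethoxy group and meta to a large group, whereas in compound 2 it sits on a six-membered aromatic ring with one nitrogen, ortho to a large group, two atoms from the ring nitrogen and meta to a trifluoromethyl group. How the two cores otherwise differ is not broken down here.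

Going by the values given here, for compound 4 the step from compound 2 is expected to be a 1.4-fold higher number from compound 2 to compound 4 (0.13 log units; within the scatter), resting on the single earlier step, which stayed within the scatter. Compound 4 is estimated at 1500 nM in this assay, with a range from 500 nM to 5000 nM.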

Compound 4, half-maximal inhibitory concentration: 1900 nM
Beside the measured number, compound 4's estimate is 1.3-fold (0.10 log units) below it; low and high end bracket the measured number.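

In this assay, putting hydrogen in place of the chloro on the core of the weaker pair gives a 1.7-fold higher number from compound 2 to compound 4 (0.24 log units; within the scatter), so this swap leaves the number within the usual scatter here, as it did on the other core. Set side by side, the two steps cannot be told apart: the same change on two cores in this assay, a 1.3-fold lower number (0.12 log units; within the scatter) from compound 3 to compound 1 and a 1.7-fold higher number (0.24 log units; within the scatter) from compound 2 to compound 4, 2.3-fold (0.36 log units) apart, within the scatter of two such steps. This shows that, in these two pairs, losing a chloro made no measurable difference, even though the chloro sits on a different ring in each; it does not show that the same would hold on any further core or at any other place, since two small steps are a thin basis for a general rule.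

The compounds shown leave open whether a different group in the same place, such as a methyl, a methoxy or a nitrile, would also leave the number unmoved on either core. They also leave open what removing the chloro that compound 1 still carries on its ring with one nitrogen would do.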